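Benzyl in Place of 4-Methylphenyl on a Ring Amine

This account rests on a few compounds, and the source may have more. Where it says the series, first, only, none or still open, it means among the compounds named here.

Compound 1 `COc1ccc(-c2cnc3nc(N)nc(OC(C)C)c3n2)cc1`: > 10000 nM
Compound 2 `COc1ccc(-c2cnc3nc(N)nc(N4CCN(c5ccc(C)cc5)CC4)c3n2)cc1OC`: 300 nM
Compound 3 `CCOc1nc(N)nc2ncc(-c3ccc(OC)cc3)nc12`: > 10000 nM

For the measured compounds named here, in a functional assay on cells (T-cell, Homo sapiens) for inhibition (a higher number here means a weaker inhibitor, a lower number a stronger inhibitor), compound 2 gives 300 nM, the only number among the three. Compound 1 reaches only the limit > 10000 nM. Compound 3 likewise reaches only the limit > 10000 nM. The step that the two limits leave unreadable from compound 1 to compound 3 cannot be read because both ends sit at the limit of > 10000 nM in this assay, at which 2 of the 3 values shown sit.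

Compound 4 `COc1ccc(-c2cnc3nc(N)nc(N4CCN(Cc5ccccc5)CC4)c3n2)cc1OC` differs from compound 2 by benzyl in place of 4-methylphenyl on an amine nitrogen in a ring. Going by the values given here, no measured step touches the amine nitrogen in the ring, so nothing in the set sizes this change. The step of a 2.7-fold higher number from compound 2 to compound 4 (0.43 log units; beyond the scatter) is therefore expected to be modest, with a loss somewhat more likely than a gain. Compound 4 is estimated at 800 nM, between 150 nM and 5000 nM.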

Compound 4, half-maximal inhibitory concentration: 900 nM
For compound 4 the middle estimate is 1.1-fold (0.05 log units) below the measured one; the measured number falls inside the stated range.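

In this assay, the amine nitrogen in the ring now has its first readable step: a 3.0-fold higher number from compound 2 to compound 4 (0.48 log units; beyond the scatter). Benzyl and 4-methylphenyl have the same 7 carbon atoms and one six-membered aromatic ring, so the position responds to how the same atoms are joined, not only to what they are. Nothing given here accounts for this step. The compounds shown leave open how a longer chain such as phenylethyl on this nitrogen would read, or an amine on the benzyl ring.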